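Sulfonamide anilide series: cytotoxicity notes toward compound 4

This account rests on a few compounds, and the source may have more. Where it says the series, first, only, none or still open, it means among the compounds named here.

Three measured amides share one core. Compound 1 `CC1(C)CCN(S(=O)(=O)c2cccc(NC(=O)c3ccc([N+](=O)[O-])s3)c2)CC1` carries a 5-nitrothiophen-2-yl on the carbonyl carbon, compound 2 `CC1(C)CCN(S(=O)(=O)c2cccc(NC(=O)c3ccc([N+](=O)[O-])o3)c2)CC1` a 5-nitrofuran-2-yl, compound 3 `CC1(C)CCN(S(=O)(=O)c2cccc(NC(=O)c3ccco3)c2)CC1` a furan-2-yl. In an ADME assay on IMR-90 cells (Homo sapiens) for cytotoxicity, read by CellTiter-Blue, with a stated time of 46 h (a lower number here means that less compound is needed, a higher number that more compound is needed for the effect), compound 1 returns only a limit, > 25000 nM. Compound 2 likewise returns only a limit, > 25000 nM. Compound 3 also stands at a limit, > 25000 nM. The measured steps are therefore a step that the two limits leave unreadable from compound 1 to compound 2, a step that the two limits leave unreadable from compound 1 to compound 3 and a step that the two limits leave unreadable from compound 2 to compound 3, because every value sits at the limit of > 25000 nM in this assay, at which 3 of the 3 values shown sit. Compound 2 thus stands nowhere above the limit; nothing in the series has yet produced a number.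

Compound 4 `O=C(Nc1cccc(S(=O)(=O)N2CCOCC2)c1)c1ccc([N+](=O)[O-])o1` differs from compound 2 by morpholin-4-yl in place of 4,4-dimethylpiperidin-1-yl on a sulfonyl sulfur. For the measured compounds named here, no measured step touches the sulfonyl substituent, and none carries a readable size, so no direction can be drawn from them. The expected step that the limit leaves unreadable from compound 2 to compound 4 is estimated as one of no readable size, most likely ending again at a limit. Compound 4 is expected at 30000 nM, with a range from 12000 nM to 80000 nM.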

Compound 4, half-maximal effective concentration: > 25000 nM
Compound 4: no number, only a limit; the forecaster's own chance of this, stated with the estimate: 85%; the middle value does not contradict the limit.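

Compound 2 and compound 4 both return only a limit, so no step between them can be read: the limit of > 25000 nM in this assay, at which 4 of the 4 values shown sit.

The compounds shown leave open where any of these amides reaches its half-maximal effect in this assay, and whether changing the group on the carbonyl carbon or on the sulfonyl sulfur shifts it.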